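This account rests on a few compounds, and the source may have more. Where it says the series, first, only, none or still open, it means among the compounds named here.

Measured compounds:
Compound 1 `COc1ccc(Cn2nc(Nc3cc(C)[nH]n3)c3ccccc3c2=O)cc1` gives 1200 nM in a functional assay on HCT-116 cells (Homo sapiens) for cytotoxicity, read by CellTiter-Glo, with a stated time of 5 days; a lower number here means a stronger inhibitor, a higher number a weaker inhibitor.
Compound 2 `Cc1cc(Nc2nn(CC(C)C)c(=O)c3ccccc23)n[nH]1` gives 1100 nM.
Compound 3 `Cc1cc(Nc2nn(Cc3ccncc3)c(=O)c3ccccc23)n[nH]1` gives 20200 nM.

Compound 1 holds the second highest of the three numbers. Its nearest neighbour is compound 2, with a 1.1-fold lower number from compound 1 to compound 2 (0.04 log units; within the scatter), a shift small enough to count as no difference. The far one is compound 3, with a 17-fold higher number from compound 1 to compound 3 (1.23 log units; beyond the scatter), and the same group swap seen from compound 2 shows an 18-fold higher number from compound 2 to compound 3 (1.26 log units; beyond the scatter). Both large steps come from putting pyridin-4-yl on the saturated chain carbon bound to the aromatic nitrogen; swapping between 4-methoxyphenyl and isopropyl there changes little.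

Compound 4 `CC(=O)Nc1ccc(Cn2nc(Nc3cc(C)[nH]n3)c3ccccc3c2=O)cc1` keeps that chain carbon and its phenyl ring and instead alters the substituent on the ring: acetamido in place of methoxy on an aromatic carbon. Among the compounds with values here, none of the measured steps touches this position, so the bearing of the data is indirect. The benzyl attachment itself is retained, and the two small steps around compound 1 suggest the core tolerates modest changes at the chain end, whereas the large steps to compound 3 warn that a more polar group can cost a great deal.

Weighing these, a modest weakening or no step beyond the scatter is expected for compound 4, estimated at 2000 nM with a range of 600 nM to 7000 nM, meaning an expected step of a 1.7-fold higher number from compound 1 to compound 4 (0.22 log units; within the scatter).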

Compound 4, half-maximal inhibitory concentration: 4200 nM
Compound 4: middle estimate off by 2.1-fold (0.32 log units), on the low side; low and high end bracket the measured number.
By their numbers in this assay, from the lowest: compounds 2 and 1 (each within the scatter of the next); then compound 4; then compound 3.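

Within the data shown here, the aromatic carbon para to a large group, which no earlier step touched, does affect the result: in this assay, acetamido in place of methoxy gives a 3.5-fold higher number from compound 1 to compound 4 (0.54 log units; beyond the scatter). Among these compounds, this is the first evidence that the substituent on this ring, and not only the group on the saturated chain carbon, can shift the number, although this single step is labelled modest. Acetamido is the larger of the two groups and brings a hydrogen-bond donor that methoxy lacks, but the data offer no measurement that explains the weakening, so neither feature can be singled out.

The compounds shown leave open whether the size of the group, its amide hydrogen or some other feature of acetamido drives this step, and an amine, a hydroxyl group or a simple hydrogen on the same carbon would help to separate these possibilities. They also leave open whether a carboxylic acid or a longer chain there would change the number further, and whether moving methoxy or acetamido to another carbon of the ring would give a similar result.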